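The compounds below may be only part of what the source reports. "The series", "measured", "known", "first", "only" and "open" are said of these compounds alone.

Working notes on a small selenium series tested in a functional assay on K562 cells (Homo sapiens) for cytotoxicity, read by MTT assay, with a stated time of 72 h; a lower number here means a stronger inhibitor of growth, a higher number a weaker inhibitor of growth. Compound 1 `C[Se]/C(=N\C(=O)c1ccco1)NC(=O)c1ccco1` gives 8780 nM. Compound 2 `O=C(/N=C(/NC(=O)c1ccco1)[Se]Cc1ccccc1)c1ccco1` gives 9530 nM in this assay. Compound 3 `O=C(/N=C(/NC(=O)c1csc([N+](=O)[O-])c1)[Se]Cc1ccccc1)c1csc([N+](=O)[O-])c1` gives 23500 nM in this assay, the highest number of the three; the difference between the core of compound 3 and the core of compound 2 is not broken down here.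

Within the data shown here, the only single-point step among the measured compounds is a 1.1-fold lower number from compound 2 to compound 1 (0.04 log units; within the scatter), which rests on one change, (hydrogen in place of phenyl on a saturated chain carbon bound to a selenium atom).

Compound 4 `C[Se]/C(=N\C(=O)c1csc([N+](=O)[O-])c1)NC(=O)c1csc([N+](=O)[O-])c1` has not yet been measured in this assay. It stands to compound 3 exactly as compound 1 stands to compound 2: hydrogen in place of phenyl on a saturated chain carbon bound to a selenium atom, the same change made on the core of compound 3, so that this change occurs twice among the compounds shown. For compound 4 the expected step is a 1.1-fold lower number from compound 3 to compound 4 (0.05 log units; within the scatter), because the same change gave a 1.1-fold lower number from compound 2 to compound 1 (0.04 log units; within the scatter), a shift that stayed within the scatter. Compound 4 is therefore estimated at 21000 nM in this assay, with a likely range from 10000 nM to 45000 nM.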

Compound 4, concentration for 50% growth inhibition: 4980 nM
Compound 4: middle estimate off by 4.2-fold (0.62 log units), on the high side; measured number outside the range, below it.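

In this assay, replacing benzyl with methyl on the core of compound 3 gives a 4.7-fold lower number from compound 3 to compound 4 (0.67 log units; beyond the scatter). Set beside the earlier step, the same change does not carry over at one size between these two cores, so a step read on one core is a poor guide to the other in this series: the same change on two cores in this assay, a 1.1-fold lower number (0.04 log units; within the scatter) from compound 2 to compound 1 and a 4.7-fold lower number (0.67 log units; beyond the scatter) from compound 3 to compound 4, 4.3-fold (0.64 log units) apart, beyond the scatter of two such steps

This rests on two pairs only, and it does not show which feature of the cores sets the gap, nor does it establish a shared direction, since the step on the core of compound 2 stays within the scatter.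

The compounds shown leave open whether the dependence on the core extends to any further core, and how much of the step on the core of compound 3 is specific to methyl. A longer chain, such as propyl or butyl, or a chain ending in an amine or a carboxylic acid, in the place of benzyl on selenium would test whether the number changes gradually or only with the loss of phenyl.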